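The source may report more compounds than this note shows. Statements on the series, on what has been measured and on what is new or still open speak of the compounds shown alone.

Among the compounds with values here, compound 1 `c1ccc(COc2nc3ccccc3s2)cc1` is the one member of this small set that comes with a number. In a functional assay on the whole organism with Mus musculus as the target, in the writhing test, at a dose of 100 mg/kg by the intraperitoneal route (on this read-out lower numbers stand for less inhibition and higher numbers for more inhibition at the one dose given (going by the name of the read-out)), compound 1 gives 51.9%, and that value is the only one in the set; compound 2 `Cc1ccc(COc2nc3ccccc3s2)cc1` was reported in this assay as "not active" (no number reported), without a number. Compound 1 therefore stands alone as the sole point of reference, while the report for compound 2 shows that the read-out need not come back as a number at all. Compound 3 `Fc1cccc(COc2nc3ccccc3s2)c1` differs from compound 1 by fluoro in place of hydrogen on an aromatic carbon. Within the data shown here, no step between measured compounds is available to set a scale for this change, so the size of the expected move is uncertain; a small fall in this assay, within the scatter, is what is expected, as in a number 9.9 percentage points lower from compound 1 to compound 3 (within the scatter). Compound 3 is thus estimated to give about 42% in this assay, between 10% and 65%.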

Compound 3, a percentage reported as inhibition, in the whole organism at one dose (the size of the read-out at that dose, not a potency): 51.9%
Estimate against measurement, compound 3: 9.9 percentage points below; the measured number falls inside the stated range.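

In this assay, within the data shown here, fluoro in place of hydrogen on an aromatic carbon, meta to a large group, gives no change at the digits printed from compound 1 to compound 3 (within the scatter) and so provides the first step in the set that can be read. It shows that this place on the six-membered aromatic ring of carbon only accepts fluoro with the read-out still coming back as a number, which the report for compound 2 had shown cannot be taken for granted. Nothing available bears on why the read-out stays where it does.

The compounds shown leave open whether a larger or differently built group at this place, such as trifluoromethyl, an amine or a carboxylic acid, would also leave the read-out in place. They also leave open whether fluoro on the other carbons of that ring would do the same.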